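From pyridin-2-yl to pyridin-3-yl: one small swap

This account rests on a few compounds, and the source may have more. Where it says the series, first, only, none or still open, it means among the compounds named here.

Within the data shown here, in a functional assay on HCT-116 cells (Homo sapiens) for antiproliferative activity, read by MTT assay, with a stated time of 48 h (on this read-out lower numbers stand for stronger inhibition and higher numbers for weaker inhibition), compound 1 (`O=C(/C=C/c1ccccn1)c1nc2ccccc2[nH]1`) gives 60 nM, the only true number so far. Compound 2 (`COc1cccc(/C=C/C(O)c2nc3ccccc3[nH]2)c1`) gives just a limit of the assay, > 100000 nM, and no number. Compound 3 (`O=C(/C=C/c1cccnc1)c1nc2ccccc2[nH]1`) has the same atoms as compound 1, joined differently, with pyridin-3-yl in place of pyridin-2-yl on a double-bonded chain carbon bound to a double-bonded chain carbon. Among the measured compounds shown here, no measured pair shows what this swap does. In this assay a moderate loss of strength is expected, an estimated 3.3-fold higher number from compound 1 to compound 3 (0.52 log units; beyond the scatter) in size. For compound 3 the expected value is 200 nM, with an estimated range from 40 nM to 2000 nM here.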

Compound 3, half-maximal inhibitory concentration: 15300 nM
Beside the measured number, compound 3's estimate is 77-fold (1.88 log units) below it; measured number above the stated range.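

In this assay this position proves highly sensitive: pyridin-3-yl in place of pyridin-2-yl, with the heavy atoms and hydrogen-bond counts of the group unchanged, gives a 260-fold higher number from compound 1 to compound 3 (2.41 log units; beyond the scatter). Among these compounds, the earlier compounds offered no measured swap at this place, so this is the first sign that the way the pyridine ring is joined to the chain matters so much. Nothing measured here accounts for the loss. Still open, on these data alone, is how a pyridin-4-yl group would fare at this place, and whether an amine on the pyridin-2-yl ring of compound 1 would keep its strength.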